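The source may hold more compounds than are shown below. What is called first, only, known or untested is meant among the compounds shown, and "the series" means these compounds.

In an in vitro ADME assay on microsomes (Homo sapiens) for metabolic stability (a lower number here means that the compound disappears faster, a higher number that the compound lasts longer), compound 1 (`CCc1nc(NC(CC)CC)c(OC)nc1-c1ccc(OC(F)F)cc1Cl`) gives 2 h and compound 2 (`CCc1nc(N(CC2CC2)CC2CC2)c(CC)nc1-c1ccc(Cl)cc1Cl`) gives 0.133 h, the lower of the two numbers and beyond the scatter from compound 1. Compound 3 (`CCCN(CC1CC1)c1nc(CC)c(-c2ccc(Cl)cc2Cl)nc1CC`) differs from compound 2 in one place: ethyl in place of cyclopropyl on a saturated chain carbon bound to a nitrogen on an aromatic ring, which reads as bis(cyclopropylmethyl)amino to (cyclopropylmethyl)(propyl)amino. Among the compounds with values here, the series holds no measured single-place step to calibrate this change, and no shift beyond the scatter is expected in this assay. The expected change is a 1.1-fold higher number from compound 2 to compound 3 (0.05 log units; within the scatter). The estimated half-life for compound 3 is 0.15 h, with an expected range of 0.07 h to 0.35 h.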

Compound 3, half-life: 0.2 h
Compound 3: the middle estimate sits 1.3-fold (0.12 log units) below what was measured, and the stated range covers the measured number.
By their numbers in this assay, from the lowest: compounds 2 and 3 (each within the scatter of the next); then compound 1.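

At the saturated chain carbon bound to a nitrogen on an aromatic ring, ethyl in place of cyclopropyl gives a 1.5-fold higher number from compound 2 to compound 3 (0.18 log units; within the scatter) in this assay. This first single-place step shows that exchanging one cyclopropylmethyl for propyl does not separate the two compounds in this read-out. Nothing available bears on the reason for this result.

Still open, on these data alone, is how a longer chain such as butyl, or a chain carrying a hydroxyl or an amine, would read at this place in this assay. As far as these compounds go, the effect of replacing the remaining cyclopropylmethyl also stays open.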